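The source may report more compounds than this note shows. Statements on the series, on what has been measured and on what is new or still open speak of the compounds shown alone.

Measured compounds:
compound 1 `C=C1[C@H](OC(C)=O)[C@H]2[C@@H](OC(=O)c3ccccc3)[C@@H](C)C[C@]2(OC(C)=O)C(=O)[C@@H](C)/C=C/C(C)(C)C(=O)[C@H](O)[C@H]1OC(=O)c1ccccc1`, compound 2 `C=C1[C@H](OC(C)=O)[C@H]2[C@@H](OC(=O)c3ccccc3)[C@](C)(O)C[C@]2(O)C(=O)[C@@H](C)/C=C/C(C)(C)C(=O)[C@H](OC(=O)C(C)C)[C@H]1OC(C)=O`, compound 3 `C=C1[C@H](OC(C)=O)[C@H]2[C@@H](OC(=O)c3ccccc3)[C@](C)(OC(C)=O)C[C@]2(O)C(=O)[C@@H](C)/C=C/C(C)(C)C(=O)[C@H](OC(=O)C(C)C)[C@H]1OC(C)=O`.

In an ADME assay on MCF7 cells (Homo sapiens) for cytotoxicity, read by MTT assay, with a stated time of 48 h (on this read-out lower numbers stand for stronger inhibition and higher numbers for weaker inhibition), compound 1 gives > 100000 nM, which is a limit of the assay rather than a number. Compound 2 likewise gives > 100000 nM, again a limit. Compound 3 gives 50200 nM. Compound 2 and compound 3 differ in one place, (acetyl in place of hydrogen on an oxygen on a saturated carbon), and this gave an at least 1.9-fold lower number from compound 2 to compound 3 (0.29 log units; that floor lies within the scatter); that compound 2 sits at the limit of > 100000 nM in this assay, at which 2 of the 3 values shown sit, means the true size of the step is not fixed. The cores of compound 1 and compound 2 differ, but that difference is not broken down here. Compound 4 `C=C1[C@H](OC(C)=O)[C@H]2[C@@H](OC(=O)c3ccccc3)[C@@H](C)C[C@]2(OC(C)=O)C(=O)[C@@H](C)/C=C/C(C)(C)C(=O)[C@H](OC(C)=O)[C@H]1OC(=O)c1ccccc1` is the unmeasured compound, and it differs from compound 1 by the same change, (acetyl in place of hydrogen on an oxygen on a saturated carbon), at a place described in the same words. The expectation for compound 4 rests on compound 1 at > 100000 nM and on the step from compound 2 to compound 3, so an estimated step of an at least 1.6-fold lower number from compound 1 to compound 4 (0.22 log units; that floor lies within the scatter) is assumed, giving an expected 60000 nM, with a range from 25000 nM to 150000 nM, and a real chance that only a limit is reported.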

Compound 4, half-maximal inhibitory concentration: > 100000 nM
Compound 4: only a limit was reported (the forecaster's own chance of this, stated with the estimate: 45%); middle value at least 1.6-fold (0.22 log units) from the limit.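

Within the data shown here, compound 1 and compound 4 both end at a limit rather than a number, so no step between them can be read: the limit of > 100000 nM in this assay, at which 3 of the 4 values shown sit. The compounds shown leave open whether acetyl in place of hydrogen changes the result in this assay on the core of compound 1.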